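Nitro in place of fluoro: expectation for compound 4

This account rests on a few compounds, and the source may have more. Where it says the series, first, only, none or still open, it means among the compounds named here.

In a functional assay on A549 cells (Homo sapiens) for antiproliferative activity, read by sulforhodamine B assay, with a stated time of 48 h (a higher number here means a weaker inhibitor, a lower number a stronger inhibitor), three members of the series have been measured. Compound 1 `COc1ccc(C(=O)/C=C\Nc2ccc(-c3nc4cc(OC)c(OC)c(OC)c4s3)cc2C)cc1O` gives 15400 nM, compound 2 `COc1cc(C(=O)/C=C\Nc2ccc(-c3nc4cc(OC)c(OC)c(OC)c4s3)cc2C)cc([N+](=O)[O-])c1OC` gives 17400 nM, and compound 3 `COc1ccc(C(=O)/C=C\Nc2ccc(-c3nc4cc(OC)c(OC)c(OC)c4s3)cc2C)cc1F` gives 1690 nM. That last number is the lowest of the three and lies beyond the scatter from both others.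

Compound 4 `COc1ccc(C(=O)/C=C\Nc2ccc(-c3nc4cc(OC)c(OC)c(OC)c4s3)cc2C)cc1[N+](=O)[O-]` is still unmeasured. It departs from compound 3 at one place: nitro in place of fluoro on an aromatic carbon. This is nitro in place of fluoro on an aromatic carbon, ortho to a methoxy group and meta to a large group, turning 3-fluoro-4-methoxyphenyl into 4-methoxy-3-nitrophenyl.

Among the compounds with values here, only one measured step involves this position: a 9.1-fold lower number from compound 1 to compound 3 (0.96 log units; beyond the scatter), with fluoro in place of hydroxy, and it lies beyond the scatter. The number in this assay therefore responds to the group placed here. Within the data shown here, no measured step isolates nitro. The closest guide is compound 2 at 17400 nM, which carries a nitro group together with a further methoxy group on that ring.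

A move to a higher number is expected, though compound 4 is not expected to lose the whole gap. The expected step is a 3.6-fold higher number from compound 3 to compound 4 (0.55 log units; beyond the scatter). For compound 4 the estimate is 6000 nM, with an expected range of 1800 nM to 20000 nM.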

Compound 4, half-maximal inhibitory concentration: 9100 nM
For compound 4 the middle estimate is 1.5-fold (0.18 log units) below the measured one; the measured number falls inside the stated range.
By their numbers in this assay, from the lowest: compound 3; then compounds 4, 1 and 2 (each within the scatter of the next).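

In this assay, nitro in place of fluoro on this aromatic carbon gives a 5.4-fold higher number from compound 3 to compound 4 (0.73 log units; beyond the scatter) and so shows that the low number of compound 3 does not carry over to every replacement of hydroxy here. Nitro in place of hydroxy gives a 1.7-fold lower number from compound 1 to compound 4 (0.23 log units; within the scatter) and so does not separate these two groups at this position, leaving fluoro as the only one of the three groups seen here that stands apart. Hydrogen in place of methoxy gives a 1.9-fold lower number from compound 2 to compound 4 (0.28 log units; within the scatter) and so shows no readable contribution from the further methoxy group on the ring of compound 2 when the nitro group is present.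

No measurement shown bears on why fluoro stands apart from hydroxy and nitro at this position, so that question stays open.

Also open, going by these compounds, is whether the low number is particular to fluoro or would also appear with chloro, nitrile or an amine on this aromatic carbon, and whether hydrogen alone here would match compound 3 or compound 4.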